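The compounds below may be only part of what the source reports. "The series", "measured", "known", "first", "only" and "open" are said of these compounds alone.

Compound 3, `COc1ccc2ncc(S(=O)(=O)c3ccc(Cl)cc3)c(N3CCC(C)CC3)c2c1`, gives 91% in an assay on isolated protein for displacement of a labelled ligand from metabotropic glutamate receptor 5 (Homo sapiens), with a stated time of 60 min, tested at 1 uM (on this read-out higher numbers stand for more inhibition at the one concentration tested (going by the name of the read-out) and lower numbers for less inhibition), the highest of the three numbers shown. Its nearest neighbour is compound 2, `COc1ccc2ncc(S(=O)(=O)c3ccc(C)c(Cl)c3)c(N3CCC(C)CC3)c2c1`, which gives 85%; the step of a number 6 percentage points higher from compound 2 to compound 3 (within the scatter) lies within the scatter. Compound 1, `COc1ccc(S(=O)(=O)c2cnc3ccc(C)cc3c2N2CCC(C)CC2)cc1`, carries a 4-methoxyphenyl on the sulfonyl sulfur together with a methyl on the core, and gives 62%, a number beyond the scatter below compound 3.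

Compound 4, `COc1ccc(S(=O)(=O)c2cnc3ccc(OC)cc3c2N2CCC(C)CC2)cc1`, is reached from compound 3 by methoxy in place of chloro on an aromatic carbon. For the measured compounds named here, no measured step changes chloro to methoxy in this place; the only step on the sulfonyl aryl, from compound 2 to compound 3, was within the scatter, while compound 1, the one measured compound with a 4-methoxyphenyl on the sulfonyl sulfur, differs from compound 3 in two places and gives the lowest number. On that basis compound 4 is expected to fall somewhat below compound 3, by a number 16 percentage points lower from compound 3 to compound 4 (beyond the scatter), an estimated 75% in this assay, in the range 55% to 92%.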

Compound 4, a percentage reported as inhibition, at one concentration (the size of the read-out at that concentration, not a potency): 41%
For compound 4 the middle estimate is 34 percentage points above the measured one, and the stated range ends above it.
By their numbers in this assay, from the lowest: compound 4; then compound 1; then compounds 2 and 3 (each within the scatter of the next).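

Where the earlier step on the sulfonyl aryl stayed within the scatter, the 4-methoxyphenyl shows that this place does matter in this assay, with a number 50 percentage points lower from compound 3 to compound 4 (beyond the scatter) and a number 44 percentage points lower from compound 2 to compound 4 (beyond the scatter) on the same core. With the 4-methoxyphenyl held fixed, the other place also responds, with methoxy in place of methyl on the core giving a number 21 percentage points lower from compound 1 to compound 4 (beyond the scatter), so the core methoxy shared with compound 2 and compound 3 does not by itself keep the number high. Nothing shown here gives a reason for either drop.

The compounds shown leave open how a fluoro, a nitrile, an amine or a carboxylic acid would read at this place on the phenyl. They also leave open how the drop would appear as a potency rather than as a number at one concentration.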